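The source may report more compounds than this note shows. Statements on the series, on what has been measured and on what is new or still open speak of the compounds shown alone.

Compound 2 `CCN(CC)C(=O)CN(c1ccc(C)cc1)S(=O)(=O)c1cccc(Cl)c1` gives, in a functional assay on CHO cells for inhibition of Orexin/Hypocretin receptor type 1 (Homo sapiens), read by FLIPR and calcium flux (on this read-out lower numbers stand for stronger inhibition and higher numbers for weaker inhibition), a value of > 10000 nM, which is a limit of the assay rather than a number. Compound 1 `CCN(CC)C(=O)CN(c1cccc(N(C)C)c1C#N)S(=O)(=O)c1ccc(OC)c(OC)c1` likewise gives only a limit in this assay, namely > 10000 nM. Within the data shown here, both results therefore sit at the limit of > 10000 nM in this assay, at which 2 of the 2 values shown sit, so no measured step can be drawn between them. Compound 3 `CCN(CC)C(=O)CN(c1ccc(C)cc1)S(=O)(=O)c1ccccc1C`, not yet measured, differs from compound 2 by 2-methylphenyl in place of 3-chlorophenyl on a sulfonyl sulfur. Among the measured compounds shown here, with no measured step of this kind to lean on, compound 3 is expected to stay near the limit, a step of about a number no higher from compound 2 to compound 3 (the limit leaves the size open), and nothing beyond the usual scatter is foreseen. Compound 3 is estimated at 10000 nM, within 3000 nM to 30000 nM.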

Compound 3, half-maximal inhibitory concentration: > 10000 nM
Compound 3: a limit, no number; the forecaster's own chance of this, stated with the estimate: 80%; the middle value sits exactly at the limit.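

Among these compounds, compound 2 and compound 3 each give only a limit in this assay and so no step between them can be read: the limit of > 10000 nM in this assay, at which 3 of the 3 values shown sit. How strongly any of these compounds inhibits the receptor stays open.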